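Removing the Hydroxy from a Citrate-Like Thioether Acid

The source may hold more compounds than are shown below. What is called first, only, known or untested is meant among the compounds shown, and "the series" means these compounds.

Compound 1 `O=C(O)CC(O)(CSCCCCCCCCCc1ccc(Cl)cc1Cl)C(=O)O`: 300000 nM
Compound 2 `O=C(O)CC(O)(CSCCCCCCc1ccc(Cl)c(Cl)c1)C(=O)O`: 110000 nM
Compound 3 `O=C(O)CC(O)CSCCCCCCc1ccc(Cl)cc1Cl`: 88000 nM

In an assay on isolated protein for inhibition of ATP-citrate synthase (Rattus norvegicus) (a lower number here means a stronger inhibitor, a higher number a weaker inhibitor), compound 3 gives 88000 nM, the lowest of the three numbers. Its gap to compound 2 is within the scatter, so no order between those two can be read from the numbers. Its gap to compound 1 is beyond the scatter, with compound 1 giving the higher number.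

Compound 4 `O=C(O)CCCSCCCCCCc1ccc(Cl)cc1Cl` differs from compound 3 in one place: hydrogen in place of hydroxy on a saturated chain carbon bound to two saturated chain carbons. Within the data shown here, none of the measured pairs isolates this change, so there is no measured step to lean on. The three measured compounds all keep the hydroxy, and all sit at weak inhibition. The step from compound 3 to compound 4 is expected to be a 2.3-fold higher number from compound 3 to compound 4 (0.36 log units; beyond the scatter) in this assay, toward a higher number, of a size that may just reach beyond the scatter. Compound 4 is therefore estimated at 200000 nM, with a range from 60000 nM to 700000 nM.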

Compound 4, inhibition constant: 25000 nM
Beside the measured number, compound 4's estimate is 8.0-fold (0.90 log units) above it, outside the stated range (below it).
By their numbers in this assay, from the lowest: compound 4; then compounds 3 and 2 (each within the scatter of the next); then compound 1.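

Among these compounds, compound 3 and compound 4 form the first measured pair that isolates the hydroxy on this saturated chain carbon bound to two saturated chain carbons. In this assay, the change from 3-carboxy-2-hydroxypropyl to 3-carboxypropyl gives a 3.5-fold lower number from compound 3 to compound 4 (0.55 log units; beyond the scatter), so this hydroxy is not required for inhibition here, and the compound without it is the stronger inhibitor of this pair. Nothing available explains the direction of this step.

From the compounds shown here alone, the step rests on this single pair, so it remains open whether removing the hydroxy would have the same effect in compound 1 and compound 2, which both carry an additional carboxylic acid. Going by these compounds, it is also open whether an amine or a methoxy group at this place would give a number closer to that of compound 3 or compound 4.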